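Piperazine Amide Replaces Methylamide in the Writhing Test

A few compounds are considered here, and "the series" means these few. Any claim that something is new, unique, unknown or untested is made for them only; others in the source may bear on it.

Three amides share the core of compound 1 `COc1cc2c(cc1OC)C(CC(N)=O)CC2`. In a functional assay on the whole organism (strain Swiss albino) for inhibition, with Mus musculus as the target, in the writhing test, with stated times of 60 min and 15 min, at a dose of 100 mg/kg by the oral route (on this read-out lower numbers stand for less inhibition and higher numbers for more inhibition at the one dose given (going by the name of the read-out)), compound 1 gives 24.6%, compound 2 `CNC(=O)CC1CCc2cc(OC)c(OC)cc21` gives 21.2% and compound 3 `COc1cc2c(cc1OC)C(CC(=O)NC1CCCCC1)CC2` gives 44.7%. Compound 2 thus holds the lowest of the three numbers, though its gap to compound 1, a number 3.4 percentage points lower from compound 1 to compound 2 (within the scatter), lies within the scatter. Compound 4 `COc1cc2c(cc1OC)C(CC(=O)N1CCNCC1)CC2` differs from compound 2 by piperazin-1-yl in place of methylamino on a carbonyl carbon. Going by the values given here, the steps that bear on this are a number 23.5 percentage points higher from compound 2 to compound 3 (beyond the scatter) and a number 20.1 percentage points higher from compound 1 to compound 3 (beyond the scatter), both beyond the scatter, where a ring on the amide-type nitrogen went with more inhibition. A ring again enters here, so a modest rise in this assay is expected, estimated as a number 10.8 percentage points higher from compound 2 to compound 4 (beyond the scatter). Compound 4 is therefore expected to give about 32%, within 18% to 48%.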

Compound 4, a percentage reported as inhibition, in the whole organism at one dose (the size of the read-out at that dose, not a potency): 68.8%
Beside the measured number, compound 4's estimate is 36.8 percentage points below it, outside the stated range (above it).
By their numbers in this assay, from the lowest: compounds 2 and 1 (each within the scatter of the next); then compound 3; then compound 4.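

In this assay piperazin-1-yl on the carbonyl carbon goes well past the amide groups seen so far, with a number 47.6 percentage points higher from compound 2 to compound 4 (beyond the scatter) and a number 44.2 percentage points higher from compound 1 to compound 4 (beyond the scatter) as large steps. A ring alone does not set the level, since a number 24.1 percentage points higher from compound 3 to compound 4 (beyond the scatter) separates two amides that both carry one. Nothing measured here accounts for this rise. Going by these compounds, how morpholin-4-yl or piperidin-1-yl would compare on this carbonyl carbon remains open. So does the effect of a methyl group on the second ring nitrogen, as in 4-methylpiperazin-1-yl.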